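Aryl esters and amides of a chloro-phenyl propylamine: series notes

The compounds below may be only part of what the source reports. "The series", "measured", "known", "first", "only" and "open" are said of these compounds alone.

Measured so far in an assay on NIH3T3 cells with Urotensin-2 receptor (Homo sapiens) as the target; on this read-out lower numbers stand for smaller maximal responses and higher numbers for larger maximal responses:
- compound 1, `COc1ccc(C(=O)OC(CCN(C)C)c2ccc(Cl)cc2)cc1`, gives 84%
- compound 2, `Cc1cccc(C(=O)OC(CCN(C)C)c2ccc(Cl)cc2)c1C`, gives 91%
- compound 3, `COc1ccc(C(=O)NC(CCN(C)C)c2ccc(Cl)cc2)cc1`, gives 162%

Compounds 1 and 2 share one core and differ only in the aryl group on the carbonyl carbon, (2,3-dimethylphenyl in place of 4-methoxyphenyl on a carbonyl carbon). That change gives a number 7 percentage points higher from compound 1 to compound 2 (within the scatter), so the two sit at the same level in this assay. Compound 3 carries a different core; how the core of compound 3 differs from the core of compound 1 is not broken down here. Compound 3 stands highest of the three, and its gap to both compound 1 and compound 2 lies beyond the scatter.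

Not yet measured is compound 4, `Cc1cccc(C(=O)NC(CCN(C)C)c2ccc(Cl)cc2)c1C`. Relative to compound 3 it shows (2,3-dimethylphenyl in place of 4-methoxyphenyl on a carbonyl carbon). Within the data shown here, this is the same kind of change as the one from compound 1 to compound 2, not the same change: there the carbonyl carbon has as its other neighbour an oxygen next to a carbonyl group, here an amide-type nitrogen.

Among the measured compounds shown here, the only guide to the effect of this change is the step from compound 1 to compound 2, which stayed within the scatter. For compound 4 a step of a number 3 percentage points higher from compound 3 to compound 4 (within the scatter) from compound 3 is therefore expected, resting on that earlier step. Compound 4 is estimated at 165%, with a likely range of 130% to 200%, given the uncertainty in carrying a step seen on one core over to another.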

Compound 4, largest response reached (reported as efficacy), in percent of the reference or control that the assay uses: 159%
Compound 4: the middle estimate sits 6 percentage points above what was measured; measured number inside the range.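

In this assay, placing 2,3-dimethylphenyl in place of 4-methoxyphenyl on a carbonyl carbon whose other neighbour is an amide-type nitrogen gives a number 3 percentage points lower from compound 3 to compound 4 (within the scatter), so this pair sits at one level, as the ester pair does. Set side by side, the two steps give no sign that the outcome of this change depends on the core: the same change on two cores in this assay, a number 7 percentage points higher (within the scatter) from compound 1 to compound 2 and a number 3 percentage points lower (within the scatter) from compound 3 to compound 4, 10 percentage points apart, within the scatter of two such steps This shows only that the swap between these two aryl groups leaves the maximal response level on both cores; with neither step beyond the scatter, it does not show that a step of real size would carry from one core to the other, and two pairs make no general rule for the series.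

Open, going by these compounds, is whether other groups on the carbonyl carbon, such as a pyridyl ring, a nitrile-bearing phenyl or a saturated cyclohexyl, would also leave the response level on both cores. Equally open, on these data alone, is how the response behaves when the dimethylamino group gives way to a pyrrolidine or a primary amine, or when a longer chain carries the amine, on either core.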